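A few compounds are considered here, and "the series" means these few. Any claim that something is new, unique, unknown or untested is made for them only; others in the source may bear on it.

Of the compounds shown here, two have so far been tested in an ADME assay on TERT-RPE1 cells (Homo sapiens) for cytotoxicity, read by resazurin assay, with a stated time of 48 h; on this read-out higher numbers stand for weaker inhibition and lower numbers for stronger inhibition. For the measured compounds named here, compound 1, with the structure `CCN/C(SC)=C(/C#N)C(=O)Nc1ccc(OCC)cc1`, is the first of them. In this assay compound 1 gives > 100000 nM, which is a limit of the assay rather than a number. Compound 2, with the structure `CCOc1ccc(-n2nnc3n[nH]c(NC)c3c2=O)cc1`, is the starting point of the step followed here. In this assay compound 2 gives > 100000 nM, again a limit of the assay and not a number. Compound 2 therefore stands where every value shown stands, namely at the limit of > 100000 nM in this assay, at which 2 of the 2 values shown sit. Going by the values given here, no step between two measured compounds can be read off, since both values are limits and the two structures differ in more than one place.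

Compound 3, with the structure `CCOc1ccc(-n2nnc3n[nH]c(Nc4ccccc4)c3c2=O)cc1`, differs from compound 2 by phenyl in place of methyl on a nitrogen on an aromatic ring. Among the compounds with values here, nothing measured so far shows a change beyond the scatter in this assay, so the step of a number no higher from compound 2 to compound 3 (the limit leaves the size open) is expected to be small, if any, in either direction. For compound 3 the expected value in this assay is 100000 nM, within a range from 30000 nM to 300000 nM, with a good chance that only a limit is reported once more.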

Compound 3, half-maximal inhibitory concentration: > 100000 nM
Compound 3: only a limit was reported; the forecaster's own chance of this, stated with the estimate: 65%; the middle value sits exactly at the limit.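

No step from compound 2 to compound 3 can be read, because both give only a limit of the assay and not a number: the limit of > 100000 nM in this assay, at which 3 of the 3 values shown sit.

The compounds shown leave open how any of them would compare by number in this assay, and so whether phenyl in place of methyl changes the read-out at all.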